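The source may report more compounds than this note shows. Statements on the series, on what has been measured and on what is new or still open speak of the compounds shown alone.

Two compounds share one core and differ only in the group carried on the oxime. Compound 1 `CN(C)/C(=N\O)c1ccc(Sc2cc(F)cc(C3CCOCC3)c2)cc1` gives 280 nM in a functional assay (blood) for inhibition, with Homo sapiens as the target; a lower number here means a stronger inhibitor, a higher number a weaker inhibitor. Compound 2 `COC(=O)c1cc(CO/N=C(\C)c2ccc(Sc3cc(F)cc(C4CCOCC4)c3)cc2)on1` gives 100 nM in this assay, the lower of the two numbers; compound 1 stands a step above it that lies beyond the usual scatter of this assay. Compound 3 `C/C(=N\OCC(=O)O)c1ccc(Sc2cc(F)cc(C3CCOCC3)c2)cc1` has not yet been measured. It is obtained from compound 2 by the change (carboxy in place of 3-(methoxycarbonyl)-1,2-oxazol-5-yl on a saturated chain carbon bound to an oxygen on an unsaturated carbon), so the ester-bearing ring at the end of the chain is replaced by a much smaller carboxylic acid. Among the compounds with values here, no pair of measured compounds shows what such a change does here, so the expectation rests on the two numbers alone. The step expected a 2.5-fold higher number from compound 2 to compound 3 (0.40 log units; beyond the scatter) is a modest loss of potency, a little beyond the scatter. Compound 3 is therefore estimated at 250 nM, with a likely range from 80 nM to 800 nM.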

Compound 3, half-maximal inhibitory concentration: 740 nM
Compound 3: middle estimate off by 3.0-fold (0.47 log units), on the low side; the range from low to high includes it.
By their numbers in this assay, from the lowest: compound 2; then compound 1; then compound 3.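

In this assay, within the data shown here, the change from 3-(methoxycarbonyl)-1,2-oxazol-5-yl to carboxy gives a 7.4-fold higher number from compound 2 to compound 3 (0.87 log units; beyond the scatter), the first sign that the group at the end of this oxime chain affects inhibition and that, of these two, the ester-bearing ring is the better one. The carboxymethyl oxime also compares poorly with the oxime-bearing group of the earlier amidoxime, with a 2.6-fold higher number from compound 1 to compound 3 (0.42 log units; beyond the scatter), so both steps point the same way and the acid sits at the weak end of this small set. No measurement at hand accounts for this loss.

Among these compounds, the single change swaps the ring and the ester for a carboxylic acid at once, so the contribution of each remains open. A methyl ester or a primary amide on the same short chain, or a carboxylic acid on a longer chain, would help to separate them.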